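A few compounds are considered here, and "the series" means these few. Any claim that something is new, unique, unknown or untested is made for them only; others in the source may bear on it.

In a functional assay on the whole organism (strain Wistar) for inhibition, with Rattus norvegicus as the target, read by paw edema, with stated times of 60 min and 6 h, at a dose of 100 mg/kg by the oral route (on this read-out lower numbers stand for less inhibition and higher numbers for more inhibition at the one dose given (going by the name of the read-out)), compound 1 `COc1cc2c(cc1OC)C(CC(=O)O)CC2` gives 20.4%. Compound 2 `COc1cc2c(cc1OC)C(CC(=O)N(C)C)CC2` gives 33.3% in this assay, and compound 3 `COc1cc2c(cc1OC)C(CC(=O)NC1CCCC1)CC2` gives 40.7%. Compound 3 thus shows the largest of the three numbers, but its gap to compound 2 lies within the scatter, while its gap to compound 1 lies beyond it. Compound 4 `COc1cc2c(cc1OC)C(CC(=O)N1CCNCC1)CC2` has not been measured in this assay. It differs from compound 3 as follows: piperazin-1-yl in place of cyclopentylamino on a carbonyl carbon. Two measured steps replaced hydroxy on the carbonyl carbon: a number 12.9 percentage points higher from compound 1 to compound 2 (beyond the scatter) and a number 20.3 percentage points higher from compound 1 to compound 3 (beyond the scatter). Within the data shown here, the one step that exchanged dimethylamino for cyclopentylamino, a number 7.4 percentage points higher from compound 2 to compound 3 (within the scatter), stayed within the scatter. The change to compound 4 is again an exchange of one group for another on the carbonyl carbon rather than a replacement of hydroxy, so no step beyond the scatter is expected in this assay. Compound 4 is therefore estimated to give 38%, with a range from 24% to 50%. The expected step is a number 2.7 percentage points lower from compound 3 to compound 4 (within the scatter).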

Compound 4, a percentage reported as inhibition, in the whole organism at one dose (the size of the read-out at that dose, not a potency): 33.3%
Beside the measured number, compound 4's estimate is 4.7 percentage points above it; measured number inside the range.
By their numbers in this assay, from the lowest: compound 1; then compounds 2, 4 and 3 (each within the scatter of the next).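

In this assay the piperazin-1-yl amide reads like the two amides before it: the exchanges are a number 7.4 percentage points lower from compound 3 to compound 4 (within the scatter) and no change at the digits printed from compound 2 to compound 4 (within the scatter) and neither separates it from them. Against the acid, the same group gives a number 12.9 percentage points higher from compound 1 to compound 4 (beyond the scatter) and so joins dimethylamino and cyclopentylamino as a third replacement of hydroxy on the carbonyl carbon that lies beyond the scatter, while a six-membered ring with 2 hetero atoms shows no readable difference from a five-membered ring of carbon only. Nothing at hand gives a reason why these amides read alike.

Open, as far as these compounds go, is whether a morpholine amide or a simple ester on the carbonyl carbon would read like these amides or like the acid. Also open, from the compounds shown here alone, is whether a longer chain between the core and the carbonyl would keep the amides together.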